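The source may report more compounds than this note shows. Statements on the series, on what has been measured and on what is new or still open speak of the compounds shown alone.

Measured in an ADME assay on MRC5 cells (Homo sapiens), read by MTT assay, with a stated time of 72 h; on this read-out higher numbers stand for weaker inhibition and lower numbers for stronger inhibition:
compound 1 `Cc1ncnc2c1c(-c1cccs1)cn2[C@@H]1O[C@H](CO)[C@@H](O)[C@H]1O`: > 100000 nM
compound 2 `Cc1ncnc2c1c(-c1ccsc1)cn2[C@@H]1O[C@H](CO)[C@@H](O)[C@H]1O`: > 100000 nM
compound 3 `CNc1ncnc2c1c(I)cn2[C@@H]1O[C@H](CO)[C@@H](O)[C@H]1O`: > 100000 nM

These are limits of the assay, not numbers, and the series shows (the limit of > 100000 nM in this assay, at which 3 of the 3 values shown sit). Compound 3 stands at that limit, > 100000 nM.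

Compound 4 `Cc1ncnc2c1c(I)cn2[C@@H]1O[C@H](CO)[C@@H](O)[C@H]1O` differs from compound 3 in one place: methyl in place of methylamino on an aromatic carbon. Among the measured compounds shown here, the only measured step, a step that the two limits leave unreadable from compound 1 to compound 2, concerns a different change and gives no size. Compound 1 already carries the entering methyl and sits at the limit > 100000 nM. Compound 2 also carries it and sits at the limit > 100000 nM. Little change is therefore expected in this assay, and any readable step could only run toward stronger inhibition. The expected step is an at least 1.2-fold lower number from compound 3 to compound 4 (0.09 log units; that floor lies within the scatter). For compound 4 the estimated value is 80000 nM, with an expected range of 20000 nM to 100000 nM.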

Compound 4, half-maximal inhibitory concentration: 13300 nM
Beside the measured number, compound 4's estimate is 6.0-fold (0.78 log units) above it; the measured number lies below the stated range.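

In this assay, methyl in place of methylamino on this aromatic carbon gives an at least 7.5-fold lower number from compound 3 to compound 4 (0.87 log units; beyond the scatter). With the methyl kept, iodo in place of thiophen-3-yl gives an at least 7.5-fold lower number from compound 2 to compound 4 (0.87 log units; beyond the scatter), and iodo in place of thiophen-2-yl gives an at least 7.5-fold lower number from compound 1 to compound 4 (0.87 log units; beyond the scatter). Among these compounds, neither the methyl with a thiophene nor the iodo with methylamino leaves the limit, and only compound 4, which joins methyl and iodo, does: the limit of > 100000 nM in this assay, at which 3 of the 4 values shown sit.

From the compounds shown here alone, it remains open how an amino group or an ethyl chain on this carbon would read with the iodo kept. Going by these compounds, it is equally open whether bromo or phenyl could take the place of iodo with the methyl kept.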